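Sulfonyl aryl variation on a phenylindole hydrazone core

The source may report more compounds than this note shows. Statements on the series, on what has been measured and on what is new or still open speak of the compounds shown alone.

Measured compounds:
compound 1 `CN1CCN(/N=C/c2c(-c3ccccc3)n(S(=O)(=O)c3ccccc3)c3ccccc23)CC1` with 1800 nM
compound 2 `CN1CCN(/N=C/c2c(-c3ccccc3)n(S(=O)(=O)c3nccn3C)c3ccccc23)CC1` with 3600 nM

Going by the values given here, compound 2 stands at the highest of the two numbers so far in a functional assay on HEK293 cells for antagonist activity at 5-hydroxytryptamine receptor 6 (Homo sapiens), read by cAMP accumulation, with stated times of 10 min and 1 h (on this read-out lower numbers stand for stronger inhibition and higher numbers for weaker inhibition), with compound 1 the nearest neighbour; the single step of a 2.0-fold higher number from compound 1 to compound 2 (0.30 log units; within the scatter) lies within the scatter, so the two cannot be ordered. Compound 3 `CN1CCN(/N=C/c2c(-c3ccccc3)n(S(=O)(=O)c3cccc4c3OCCO4)c3ccccc23)CC1` is not yet measured. It differs from compound 2 in one place: 2,3-dihydro-1,4-benzodioxin-5-yl in place of 1-methyl-1H-imidazol-2-yl on a sulfonyl sulfur. Among the compounds with values here, only one measured step bears on this position, the exchange of phenyl for 1-methyl-1H-imidazol-2-yl on the sulfonyl sulfur, and that step did not leave the scatter. The entering group again carries a six-membered aromatic ring of carbon only, as in compound 1, so no step beyond the scatter is expected in this assay. For compound 3 the estimate is 2500 nM (range 800 nM to 8000 nM), which means an expected step of a 1.4-fold lower number from compound 2 to compound 3 (0.16 log units; within the scatter).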

Compound 3, half-maximal inhibitory concentration: 3800 nM
Estimate against measurement, compound 3: 1.5-fold (0.18 log units) below, and the stated range covers the measured number.
By their numbers in this assay, from the lowest: compounds 1, 2 and 3 (each within the scatter of the next, the first and the last beyond it).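

Placing 2,3-dihydro-1,4-benzodioxin-5-yl on the sulfonyl sulfur instead of 1-methyl-1H-imidazol-2-yl gives a 1.1-fold higher number from compound 2 to compound 3 (0.02 log units; within the scatter) in this assay. The two groups therefore cannot be told apart here, even though the entering group has more heavy atoms and a different ring make-up. Going by these compounds alone, measured against phenyl, the same group gives a 2.1-fold higher number from compound 1 to compound 3 (0.32 log units; beyond the scatter) as the only step at this position that leaves the scatter; it is modest, and it places compound 3 as the weaker inhibitor relative to compound 1. Nothing at hand accounts for either step.

Left open is whether a methyl group, a pyridyl group or a naphthyl group on the sulfonyl sulfur would stand clear of these three compounds. Also open, going by these compounds, is how a carboxylic acid or an amine carried on the phenyl ring of compound 1 would read.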